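Fluorine on the outer phenyl: compound 3 to compound 4

A few compounds are considered here, and "the series" means these few. Any claim that something is new, unique, unknown or untested is made for them only; others in the source may bear on it.

Measured compounds:
compound 1 `Cc1ccccc1-n1cc(-c2ccccc2NS(=O)(=O)c2c[nH]c(=O)[nH]c2=O)nn1` gives 13900 nM in a functional assay on HepG2 cells (Homo sapiens) for antiproliferative activity, read by MTT assay, with a stated time of 24 h; a higher number here means a weaker inhibitor, a lower number a stronger inhibitor
compound 2 `O=c1[nH]cc(S(=O)(=O)Nc2ccccc2-c2cn(-c3ccc(F)cc3)nn2)c(=O)[nH]1` gives > 20000 nM
compound 3 `O=c1[nH]cc(S(=O)(=O)Nc2cccc(-c3cn(-c4ccccc4)nn3)c2)c(=O)[nH]1` gives 11200 nM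

In this assay compound 3 holds the lowest of the two plain numbers, and compound 1 sits within the scatter of it. Compound 2 reaches only a limit of this assay, (the limit of > 20000 nM in this assay, at which 1 of the 3 values shown sits).

Compound 4 `O=c1[nH]cc(S(=O)(=O)Nc2cccc(-c3cn(-c4ccc(F)cc4)nn3)c2)c(=O)[nH]1` differs from compound 3 by fluoro in place of hydrogen on an aromatic carbon, on the ring at the aromatic nitrogen, para to a large group. Among the compounds with values here, the only related step is an at least 1.4-fold higher number from compound 1 to compound 2 (0.15 log units; that floor lies within the scatter), which also swaps in a 4-fluorophenyl at that nitrogen. A small rise in the number, or none beyond the scatter, is therefore expected for a 1.5-fold higher number from compound 3 to compound 4 (0.18 log units; within the scatter). Compound 4 is estimated at 17000 nM, between 9000 nM and 32000 nM.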

Compound 4, half-maximal inhibitory concentration: > 20000 nM
Compound 4: no number, only a limit; the forecaster's own chance of this, stated with the estimate: 35%; at least 1.1-fold (0.07 log units) between middle value and limit.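

In this assay compound 4 gives > 20000 nM as a limit and not a number. With no methyl group leaving at the same time, fluoro in place of hydrogen can be read alone here, as an at least 1.7-fold higher number from compound 3 to compound 4 (0.25 log units; that floor lies within the scatter) and so a loss is possible but not shown, with its true size unknown. Compound 2 and compound 4, the two compounds with a 4-fluorophenyl, end at the same limit: the limit of > 20000 nM in this assay, at which 2 of the 4 values shown sit.

From the compounds shown here alone, whether a chlorine, a methoxy group or an amine in that place would bring a measurable number stays open.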